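This account rests on a few compounds, and the source may have more. Where it says the series, first, only, none or still open, it means among the compounds named here.

Compound 2 `O=C(NOCc1ccccc1)c1cn(-c2ccccc2)nc1-c1ccc(Cl)cc1` and compound 1 `O=C(NOCc1ccccc1F)c1cn(-c2ccccc2)nc1-c1ccccc1` share a common core and differ from each other at more than one place. In an ADME assay on HEK-293T cells (Homo sapiens) for antiproliferative activity, read by MTT assay, with a stated time of 48 h, in the presence of a further agent that is not named here (a higher number here means that more compound is tolerated, a lower number that less compound is tolerated), compound 2 gives 51900 nM and compound 1 gives 75700 nM, two numbers that lie within the usual scatter of each other, so neither can be called more or less tolerated. Compound 3 `O=C(NOCc1ccccc1F)c1cn(-c2ccccc2)nc1-c1ccc(Cl)cc1` differs from compound 2 by fluoro in place of hydrogen on an aromatic carbon. Within the data shown here, no measured pair shows this exact change, so the expected step is small: the step of a 1.2-fold higher number from compound 2 to compound 3 (0.06 log units; within the scatter) is estimated to stay within the scatter. Compound 3 is expected to give 60000 nM, with a range from 25000 nM to 130000 nM.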

Compound 3, half-maximal cytotoxic concentration: 126000 nM
Estimate against measurement, compound 3: 2.1-fold (0.32 log units) below; the measured number falls inside the stated range.
By their numbers in this assay, from the lowest: compounds 2, 1 and 3 (each within the scatter of the next, the first and the last beyond it).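

In this assay, going from benzyl to 2-fluorobenzyl gives a 2.4-fold higher number from compound 2 to compound 3 (0.39 log units; beyond the scatter), so this one added atom, ortho to a large group, produces a modest but readable change where the chloro group is present. Chloro in place of hydrogen gives a 1.7-fold higher number from compound 1 to compound 3 (0.22 log units; within the scatter), so that change cannot be read in either direction. Nothing shown here explains the fluoro step.

Going by these compounds, it remains open what a methyl or methoxy group would give at this place. On these data alone, whether fluoro gives a similar step without chloro also remains open.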